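A few compounds are considered here, and "the series" means these few. Any claim that something is new, unique, unknown or untested is made for them only; others in the source may bear on it.

In a functional assay on DU-145 cells (Homo sapiens) for inhibition, read by MTT assay, with a stated time of 48 h (on this read-out lower numbers stand for stronger inhibition and higher numbers for weaker inhibition), three compounds sharing one core have been tested so far. Compound 1 `Cn1c(/C=C2\SC(=O)N(CC(=O)Nc3cc(C(C)(C)C)on3)C2=O)nc2ccccc21` gives a measured 31400 nM. Compound 2 `CCn1c(/C=C2\SC(=O)N(CC(=O)N3CCCCC3)C2=O)nc2ccccc21` gives only a limit of the assay, > 50000 nM, and not a number. Compound 3 `CC(C)n1c(/C=C2\SC(=O)N(CC(=O)N3CCCC3)C2=O)nc2ccccc21` also gives only a limit, > 50000 nM. Compound 2 therefore stands at the limit of > 50000 nM in this assay, at which 2 of the 3 values shown sit.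

Compound 4 `CCn1c(/C=C2\SC(=O)N(CC(=O)N3CCOCC3)C2=O)nc2ccccc21` is still unmeasured. It carries morpholin-4-yl in place of the piperidin-1-yl of compound 2, on a carbonyl carbon: morpholin-4-yl in place of piperidin-1-yl on a carbonyl carbon. Among the compounds with values here, no measured pair shows what this swap does in this assay, so no change beyond the usual scatter is expected. The estimated size of the step that the limit leaves unreadable from compound 2 to compound 4 stays within that scatter, and another limit is the likeliest result. Compound 4 is estimated at 55000 nM, with an expected range from 30000 nM to 100000 nM.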

Compound 4, half-maximal inhibitory concentration: > 50000 nM
Compound 4: a limit, no number (the forecaster's own chance of this, stated with the estimate: 75%); the middle value is on the limit's open side.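

Within the data shown here, compound 2 and compound 4 both give only a limit of the assay and not a number, so no step between them can be read: the limit of > 50000 nM in this assay, at which 3 of the 4 values shown sit. The compounds shown leave open what morpholin-4-yl in place of piperidin-1-yl on a carbonyl carbon does to inhibition.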